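From Dimethylamino to Piperidin-1-yl on a Shared Core

This account rests on a few compounds, and the source may have more. Where it says the series, first, only, none or still open, it means among the compounds named here.

Two measured compounds share one core. Compound 1 `CCN(CC)CN1C(=O)/C(=N\c2nc3ccc(C)cc3s2)c2c(Br)cccc21` in an ADME assay on MCF-10A cells (Homo sapiens) for cytotoxicity, read by sulforhodamine B assay, with a stated time of 48 h (a lower number here means a stronger inhibitor of growth, a higher number a weaker inhibitor of growth), gives 16100 nM. Compound 2 `Cc1ccc2nc(/N=C3\C(=O)N(CN(C)C)c4cccc(Br)c43)sc2c1` gives 21800 nM in this assay. Among the compounds with values here, the single step between them, a 1.4-fold higher number from compound 1 to compound 2 (0.13 log units; within the scatter), comes from dimethylamino in place of diethylamino on a saturated chain carbon bound to an amide-type nitrogen in a ring. Compound 2 thus holds the highest of the two numbers, yet its gap to compound 1 lies within the scatter, so no order between them can be claimed.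

Compound 3 `Cc1ccc2nc(/N=C3\C(=O)N(CN4CCCCC4)c4cccc(Br)c43)sc2c1` has not been measured. It differs from compound 2 by piperidin-1-yl in place of dimethylamino on a saturated chain carbon bound to an amide-type nitrogen in a ring. Within the data shown here, the only step that bears on this change is the one between compound 1 and compound 2, which varied the same group at the same place and moved the number within the scatter. On that basis the expected step is a 1.1-fold lower number from compound 2 to compound 3 (0.06 log units; within the scatter), with no direction beyond the scatter. Compound 3 is expected to give 19000 nM in this assay, within a range from 8000 nM to 45000 nM.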

Compound 3, concentration for 50% growth inhibition: 18400 nM
Compound 3: middle estimate off by 1.0-fold (0.01 log units), on the high side, and the stated range covers the measured number.
By their numbers in this assay, from the lowest: compounds 1, 3 and 2 (each within the scatter of the next).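

Piperidin-1-yl in place of dimethylamino on a saturated chain carbon bound to an amide-type nitrogen in a ring gives a 1.2-fold lower number from compound 2 to compound 3 (0.07 log units; within the scatter) in this assay, and piperidin-1-yl in place of diethylamino at the same place gives a 1.1-fold higher number from compound 1 to compound 3 (0.06 log units; within the scatter). Earlier, only two open-chain amines had been compared at this position; with a six-membered non-aromatic ring now included, the three amines still show no order, and the ring brings no step beyond the scatter from either open-chain group. No accompanying evidence explains why the three numbers stay so close.

The compounds shown leave open whether any group on this chain carbon can move the number beyond the scatter, for instance morpholin-4-yl, which carries an oxygen in its ring, or a carboxylic acid in place of the amine. They also leave open what would follow from replacing the bromine or the methyl on the shared core, as all three compounds carry both.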